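What Losing the Hydroxy Group May Cost Compound 1

A few compounds are considered here, and "the series" means these few. Any claim that something is new, unique, unknown or untested is made for them only; others in the source may bear on it.

In a functional assay on HUVEC cells (Homo sapiens) for inhibition, read by ELISA and BrdU incorporation (a higher number here means a weaker inhibitor, a lower number a stronger inhibitor), compound 1 `O=C(Nc1cccc2cccnc12)c1cc(Br)cnc1O` gives 12.9 nM. Compound 2 `Cc1cnc(O)c(C(=O)Nc2cccc3cccnc23)c1` gives 13.6 nM, level with it within the scatter. Compound 3 `O=C(Nc1cccc2cccnc12)c1ccc(Cl)nc1` gives 141 nM, a clearly higher number, so compound 1 shares the strong end of this small set with compound 2.

The compound still to be measured is compound 4 `O=C(Nc1cccc2cccnc12)c1cncc(Br)c1`, and it differs from compound 1 in one place: hydrogen in place of hydroxy on an aromatic carbon. The new hydrogen sits next to the ring nitrogen, ortho to a large group and para to a bromo group.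

Within the data shown here, the only measured step that changes one place is a 1.1-fold higher number from compound 1 to compound 2 (0.02 log units; within the scatter), with methyl in place of bromo. That step leaves the hydroxy untouched, so it says nothing direct about this change. The closest hint comes from compound 3, which carries no hydroxy and gives 141 nM, although it also differs from compound 1 elsewhere.

A step to a higher number in this assay, meaning a weaker inhibitor, is therefore expected, though its size is uncertain. The expected step is a 7.8-fold higher number from compound 1 to compound 4 (0.89 log units; beyond the scatter). For compound 4 the estimated value is 100 nM, with an expected range of 25 nM to 400 nM.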

Compound 4, half-maximal inhibitory concentration: 211 nM
Compound 4: the middle estimate sits 2.1-fold (0.32 log units) below what was measured; the range from low to high includes it.
By their numbers in this assay, from the lowest: compounds 1 and 2 (each within the scatter of the next); then compounds 3 and 4 (each within the scatter of the next).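

In this assay, among these compounds, swapping the hydroxy group for hydrogen is the first single change in this set that moves the number beyond the scatter: a 16-fold higher number from compound 1 to compound 4 (1.21 log units; beyond the scatter). That hydroxy sits on an aromatic carbon next to the ring nitrogen, and the result shows that this one atom of oxygen matters a great deal for the inhibition seen with compound 1, whereas the other single change on the same ring, methyl in place of bromo, gives only a 1.1-fold higher number from compound 1 to compound 2 (0.02 log units; within the scatter). So, among these compounds, the ring tolerates a change at the bromo group but not the loss of the hydroxy, although nothing available here explains why removing it costs so much.

The compounds shown leave open whether another group in the same place, such as an amine, a methoxy or a fluoro, could hold the number near that of compound 1, or whether only hydroxy does so. As far as these compounds go, it also remains open whether hydrogen in place of hydroxy would cost as much with the methyl of compound 2 on the ring as it does with the bromo of compound 1.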